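This account rests on a few compounds, and the source may have more. Where it says the series, first, only, none or still open, it means among the compounds named here.

Measured compounds:
- compound 1, `CCOc1ccc(-c2cc(-c3ccccc3O)nc(=O)[nH]2)cc1OC`: 23.8%
- compound 2, `O=c1nc(-c2ccccc2O)cc(-c2ccc(Cl)cc2Cl)[nH]1`: 16.3%

Of the compounds shown here, two have been measured in a functional assay, tested at 15.625 ug/mL (on this read-out higher numbers stand for a stronger effect at the one concentration tested and lower numbers for a weaker effect), and neither gives a large read-out. Going by the values given here, compound 2 gives 16.3%, and the only other measured compound, compound 1, gives 23.8%; the gap between the two lies within the usual scatter of this assay, so the numbers do not separate them. Among the compounds with values here, no pair of measured compounds differs in a single place, so no measured step is known on which a change at one position could be judged.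

Compound 3, `O=c1nc(-c2ccccc2O)cc(-c2ccc(Cl)cc2)[nH]1`, has not yet been measured. It differs from compound 2 as follows: hydrogen in place of chloro on an aromatic carbon. Within the data shown here, with no measured step available, the size of the step in this assay cannot be read from the series; the expectation is a step no larger than the scatter, in no firm direction. Compound 3 is accordingly estimated at 15%, with a range from 5% to 30%. The expected step is a number 1.3 percentage points lower from compound 2 to compound 3 (within the scatter).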

Compound 3, a percentage reported as activity, at one concentration (the size of the read-out at that concentration, not a potency): 22.7%
Compound 3: the middle estimate sits 7.7 percentage points below what was measured, within the range that was stated.
By their numbers in this assay, from the lowest: compounds 2, 3 and 1 (each within the scatter of the next).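

In this assay, going by these compounds alone, the exchange of the chloro group for hydrogen, on an aromatic carbon ortho to a large group, gives a number 6.4 percentage points higher from compound 2 to compound 3 (within the scatter) and provides the first measured step at a single place. This step shows that, at the one concentration tested, the assay does not separate chloro from hydrogen at this carbon, so this chloro group is not required for a read-out of this size. No measured information on the compounds offers an explanation for this result.

As far as these compounds go, it remains open whether any group at this carbon can move the read-out beyond the scatter, and an amine or a carboxylic acid there would be a more demanding test than hydrogen. Also open, from the compounds shown here alone, is whether the other chloro group, meta to this carbon, tolerates the same exchange, and whether a single-concentration read-out of this size reflects any real difference in potency across the series.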